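Working notes: compound 1 to compound 4 in glucagon binding

The compounds below may be only part of what the source reports. "The series", "measured", "known", "first", "only" and "open" are said of these compounds alone.

Among the compounds with values here, compound 1 `C[C@H](c1ccc(C(=O)NCCC(=O)O)cc1)N1C(=O)C(c2cccc(C3CC3)c2)=N[C@]12CC[C@@H](C(C)(C)C)CC2` is the weakest binder among the three compounds measured so far: in an assay on membranes from liver for displacement of a labelled ligand from Glucagon receptor (Mus musculus), read by scintillation counting, with a stated time of 60 min (a lower number here means a stronger inhibitor, a higher number a weaker inhibitor), compound 1 gives 1700 nM. Compound 2 `CCCCC[C@H](c1ccc(C(=O)NCc2nn[nH]n2)cc1)N1C(=O)C(c2cc(Cl)cc(Cl)c2)=N[C@]12CC[C@@H](C(C)(C)C)CC2` gives 310 nM in this assay, and compound 3 `CC(C)(C)CC[C@H](c1ccc(C(=O)NCc2nn[nH]n2)cc1)N1C(=O)C(c2ccc(F)cc2)=N[C@]12CC[C@@H](C(C)(C)C)CC2` gives 90 nM; both numbers are lower than that of compound 1 by margins beyond the scatter. Compound 4 `C[C@H](c1ccc(C(=O)NCCC(=O)O)cc1)N1C(=O)C(c2cccc(OC(F)(F)F)c2)=N[C@]12CC[C@@H](C(C)(C)C)CC2` has not yet been measured in this assay. It differs from compound 1 in one place: trifluoromethoxy in place of cyclopropyl on an aromatic carbon. Within the data shown here, no measured pair shows this change, so there is no step to draw on. The change is expected to shift this assay little, if at all, with a 1.2-fold lower number from compound 1 to compound 4 (0.08 log units; within the scatter) expected to lie within the scatter. For compound 4 the estimate is 1400 nM, with a range from 500 nM to 4000 nM.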

Compound 4, half-maximal inhibitory concentration: 1500 nM
For compound 4 the middle estimate is 1.1-fold (0.03 log units) below the measured one; measured number inside the range.
By their numbers in this assay, from the lowest: compound 3; then compound 2; then compounds 4 and 1 (each within the scatter of the next).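

In this assay, within the data shown here, replacing 3-cyclopropylphenyl with 3-(trifluoromethoxy)phenyl gives a 1.1-fold lower number from compound 1 to compound 4 (0.05 log units; within the scatter), the first one-place comparison. At this position on the aromatic ring, the two groups cannot be told apart, despite their different atoms and the loss of the ring. No available evidence bears on this result.

Going by these compounds, whether an amine or a nitrile at this position would read the same remains open. Compounds 2 and 3 differ from compound 1 in more than one place, so their lower numbers cannot be assigned to any single group.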